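A few compounds are considered here, and "the series" means these few. Any claim that something is new, unique, unknown or untested is made for them only; others in the source may bear on it.

Measured so far in an assay on isolated protein for displacement of a labelled ligand from 5-hydroxytryptamine receptor 6 (Homo sapiens), read by scintillation counting, with a stated time of 1 h; a higher number here means a weaker inhibitor, a lower number a stronger inhibitor:
compound 1 `O=S(=O)(c1ccccc1)n1cc(N2CCCCC2)c2ccccc21` gives 219 nM;
compound 2 `CN(C)c1cn(S(=O)(=O)c2ccccc2)c2ccccc12` gives 474 nM;
compound 3 `O=S(=O)(c1ccccc1)n1ccc2cc(N3CCCCC3)ccc21` gives 360 nM.

Compound 1 and compound 2 differ in one place, (dimethylamino in place of piperidin-1-yl on an aromatic carbon); this step is a 2.2-fold higher number from compound 1 to compound 2 (0.34 log units; beyond the scatter). Compound 3 has the same atoms as compound 1, joined differently, and the difference between the two cores is not broken down here. Compound 4 `CN(C)c1ccc2c(ccn2S(=O)(=O)c2ccccc2)c1` is not yet measured; it differs from compound 3 by dimethylamino in place of piperidin-1-yl on an aromatic carbon. In the first pair the place is on an aromatic carbon of a five-membered aromatic ring with 1 nitrogen; in the second it is on an aromatic carbon of a six-membered aromatic ring of carbon only, meta and para to a fused ring, so this is the same kind of change, not the same one. Compound 4 is expected to take a step of a 2.1-fold higher number from compound 3 to compound 4 (0.32 log units; beyond the scatter), on the assumption that it resembles the step seen for compound 1 and compound 2, a 2.2-fold higher number from compound 1 to compound 2 (0.34 log units; beyond the scatter). Compound 4 is therefore estimated at 750 nM, between 300 nM and 1900 nM.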

Compound 4, inhibition constant: 82 nM
The estimate for compound 4 lay 9.1-fold (0.96 log units) above the measured number; the measured number lies below the stated range.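

In this assay, dimethylamino in place of piperidin-1-yl gave a 4.4-fold lower number from compound 3 to compound 4 (0.64 log units; beyond the scatter), so the change did not carry over between the two cores and its direction reversed: the same change on two cores in this assay, a 2.2-fold higher number (0.34 log units; beyond the scatter) from compound 1 to compound 2 and a 4.4-fold lower number (0.64 log units; beyond the scatter) from compound 3 to compound 4, 9.5-fold (0.98 log units) apart, beyond the scatter of two such steps. In this series, then, the step measured on the core of compound 1 could not be transferred to the core of compound 3. These two pairs do not show why the steps differ, nor how the change would behave on any further core.

The compounds shown leave open whether a pyrrolidin-1-yl or morpholin-4-yl group would follow dimethylamino or piperidin-1-yl at these two places. They also leave open whether a primary amine would reverse in the same way between the two cores.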